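The source may report more compounds than this note shows. Statements on the series, on what has been measured and on what is new or still open speak of the compounds shown alone.

Of the compounds shown here, three built on one shared core have been tested in an assay on isolated protein for displacement of a labelled ligand from metabotropic glutamate receptor 5 (Homo sapiens), with a stated time of 60 min, tested at 1 uM; on this read-out higher numbers stand for more inhibition at the one concentration tested (going by the name of the read-out) and lower numbers for less inhibition. Compound 1 `Cc1ccc2ncc(S(=O)(=O)c3ccc(C)c(Cl)c3)c(N3CCC(C)CC3)c2c1` gives 91%. Compound 2 `COc1cccc(S(=O)(=O)c2cnc3ccc(OC)cc3c2N2CCC(C)CC2)c1` gives 0%, while compound 3 `COc1ccc2ncc(S(=O)(=O)c3ccc(C)cc3)c(N3CCC(C)CC3)c2c1` gives 90%. Compound 3 thus stands with compound 1 among the high numbers: its step from compound 2 is large, a number 90 percentage points higher from compound 2 to compound 3 (beyond the scatter), whereas the number for compound 1 differs from it only within the scatter of this assay.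

Compound 4 `COc1ccc2ncc(S(=O)(=O)c3ccc(C)c(Cl)c3)c(N3CCC(C)CC3)c2c1` has not been measured. It differs from compound 3 in one place: chloro in place of hydrogen on an aromatic carbon. The chloro enters ortho to a methyl group on the ring attached to the sulfonyl sulfur. Going by the values given here, no measured step isolates this exact change. Compound 1 carries the same 3-chloro-4-methylphenyl group on its sulfonyl sulfur together with a different substituent on the core, and its value of 91% sits within the scatter of compound 3. Among the compounds with values here, the one large step, a number 90 percentage points higher from compound 2 to compound 3 (beyond the scatter), concerns a different change on that ring. Compound 4 is therefore expected to show no step beyond the scatter, a number 1 percentage points higher from compound 3 to compound 4 (within the scatter). Compound 4 is estimated at 91%, with a range from 80% to 98%.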

Compound 4, a percentage reported as inhibition, at one concentration (the size of the read-out at that concentration, not a potency): 85%
The estimate for compound 4 lay 6 percentage points above the measured number, within the range that was stated.
By their numbers in this assay, from the lowest: compound 2; then compounds 4, 3 and 1 (each within the scatter of the next).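

In this assay, placing chloro ortho to a methyl group on the ring attached to the sulfonyl sulfur gives a number 5 percentage points lower from compound 3 to compound 4 (within the scatter) and so leaves the number where it was, as far as the scatter can tell. The large gap to the 3-methoxyphenyl group survives this addition, with a number 85 percentage points higher from compound 2 to compound 4 (beyond the scatter) for the change to 3-chloro-4-methylphenyl, and with that group in place, a number 6 percentage points lower from compound 1 to compound 4 (within the scatter) shows that methoxy and methyl on the core cannot be told apart here. Nothing measured for these compounds offers an explanation for these results.

On these data alone, whether this place on the ring would accept something other than chloro, such as bromo, an amine or a carboxylic acid, stays open. Also open, as far as these compounds go, is whether the methyl group is needed once the chloro is present, as a 3-chlorophenyl group would show.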